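This account rests on a few compounds, and the source may have more. Where it says the series, first, only, none or still open, it means among the compounds named here.

Compound 1, `CC(=O)N[C@@H]1CCC[C@H](C(=O)Nc2cc(-c3cnn(C)c3C)c(Cl)cn2)C1`, gives 10 uL/min in an ADME assay on cells (Hepatocyte, Rattus norvegicus) for metabolic stability, using equilibrium dialysis; a higher number here means faster removal of the compound, a lower number slower removal.
Compound 2, `CC(=O)N[C@@H]1CCC[C@H](C(=O)Nc2cc(-c3cnc4n3CCCC4)c(Cl)cn2)C1`, gives 12 uL/min in this assay.
Compound 3, `CC(=O)N[C@@H]1CCC[C@H](C(=O)Nc2cc(-c3cnn4c3COCC4)c(Cl)cn2)C1`, gives 18 uL/min in this assay.

All three compounds share the same core and differ only in the group attached to one aromatic carbon. The three numbers lie close together: the step of a 1.8-fold higher number from compound 1 to compound 3 (0.26 log units; within the scatter) and the step of a 1.5-fold higher number from compound 2 to compound 3 (0.18 log units; within the scatter) both fall inside the usual scatter, as does a 1.2-fold higher number from compound 1 to compound 2 (0.08 log units; within the scatter), so compound 3 cannot be set apart from the other two on these numbers.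

Compound 4, `CC(=O)N[C@@H]1CCC[C@H](C(=O)Nc2cc(-c3cnc4n3CC(C)(C)C4)c(Cl)cn2)C1`, has not yet been measured in this assay. Its change from compound 3 is a group of 10 heavy atoms (8 carbon, 2 nitrogen; one five-membered non-aromatic ring with 1 hetero atom, one five-membered aromatic ring with 2 hetero atoms) in place of a group of 9 heavy atoms (6 carbon, 2 nitrogen, 1 oxygen; one five-membered aromatic ring with 2 hetero atoms, one six-membered non-aromatic ring with 2 hetero atoms), on an aromatic carbon. The steps seen so far, each of which swaps one such group for another at this same carbon, stayed within the scatter, so no step beyond the scatter is expected here either. The estimate for compound 4 is 13 uL/min, with a range from 6 uL/min to 26 uL/min, which as a step means a 1.4-fold lower number from compound 3 to compound 4 (0.14 log units; within the scatter).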

Compound 4, intrinsic clearance in a liver preparation (reported as CLH), per the amount of preparation that the assay uses: 28 uL/min
Compound 4: the middle estimate sits 2.2-fold (0.33 log units) below what was measured, and the stated range ends below it.
By their numbers in this assay, from the lowest: compounds 1, 2, 3 and 4 (each within the scatter of the next, the first and the last beyond it).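

In this assay, this aromatic carbon now shows that a swap of group here can move the number beyond the usual scatter: the group with the five-membered non-aromatic ring gives a 2.3-fold higher number from compound 2 to compound 4 (0.37 log units; beyond the scatter) and a 2.8-fold higher number from compound 1 to compound 4 (0.45 log units; beyond the scatter), both modest. Among the compounds shown here, the same group still cannot be told apart from the one in compound 3, as a 1.6-fold higher number from compound 3 to compound 4 (0.19 log units; within the scatter) shows, so the four compounds form a gradual series, with only its far ends separated. No measurement shown here explains these differences.

The group in compound 4 differs from that in compound 2 in both ring size and atom count, so the two changes cannot be separated here. From the compounds shown here alone, how an amine or a carboxylic acid on the five-membered aromatic ring would behave at this carbon also remains open.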